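Moving the Methoxy Group on a Bombesin Receptor Agonist

The compounds below may be only part of what the source reports. "The series", "measured", "known", "first", "only" and "open" are said of these compounds alone.

In an in vitro functional assay on cells for agonist activity at Bombesin receptor subtype-3 (Homo sapiens), read by luminescence and calcium flux (a lower number here means that less compound is needed, a higher number that more compound is needed for the effect), compound 1 `O=C(O)c1ccccc1-c1ccc(CCc2ncc(CC3CCOCC3)[nH]2)cc1` gives 338 nM, while compound 2 `COc1cccc(Cc2cnc(CCc3ccc(-c4ccccc4C(=O)O)cc3)[nH]2)c1` gives 4120 nM, the higher of the two numbers shown. Going by the values given here, the only measured step, a 12-fold higher number from compound 1 to compound 2 (1.09 log units; beyond the scatter), exchanged one whole group for another. Compound 3 `COc1ccc(Cc2cnc(CCc3ccc(-c4ccccc4C(=O)O)cc3)[nH]2)cc1` differs from compound 2 by 4-methoxyphenyl in place of 3-methoxyphenyl on a saturated chain carbon bound to an aromatic carbon, a change that keeps the same atoms and only moves the methoxy group on the ring. Among the compounds with values here, no measured step tests such a move, so the data give no direct guide. Compound 3 is therefore expected at an estimated 4000 nM, with a range from 1300 nM to 12000 nM. The step of a 1.0-fold lower number from compound 2 to compound 3 (0.01 log units; within the scatter) is expected to stay within the scatter.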

Compound 3, half-maximal effective concentration: 5360 nM
Compound 3: the middle estimate sits 1.3-fold (0.13 log units) below what was measured, and the stated range covers the measured number.
By their numbers in this assay, from the lowest: compound 1; then compounds 2 and 3 (each within the scatter of the next).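

In this assay, a 1.3-fold higher number from compound 2 to compound 3 (0.11 log units; within the scatter) shows that, on a saturated chain carbon bound to an aromatic carbon, 3-methoxyphenyl and 4-methoxyphenyl cannot be told apart. With a 16-fold higher number from compound 1 to compound 3 (1.20 log units; beyond the scatter) lying beyond the scatter, the large gap from oxan-4-yl now appears with both methoxyphenyl groups, so moving the methoxy group between these two ring places does not close it. Still open, as far as these compounds go, is whether an amine on that ring, or a longer chain in place of the methoxy group, would bring the number nearer to that of compound 1. Nothing given here accounts for the gap between oxan-4-yl and the methoxyphenyl groups.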